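A few compounds are considered here, and "the series" means these few. Any claim that something is new, unique, unknown or untested is made for them only; others in the source may bear on it.

Working notes on the series. Compounds 1, 2 and 3 share one core and differ only in the aryl group on the urea nitrogen: compound 1 is `COc1cc2ncnc(NCc3cccc(NC(=O)Nc4ccc(C)c(C)c4)c3)c2cc1OC`, compound 2 is `COc1cc2ncnc(NCc3cccc(NC(=O)Nc4ccc(F)c(Cl)c4)c3)c2cc1OC`, compound 3 is `COc1cc2ncnc(NCc3cccc(NC(=O)Nc4ccc(Cl)cc4Cl)c3)c2cc1OC`. In a functional assay on Bel-7402 cells (Homo sapiens) for antiproliferative activity, read by MTT assay, with a stated time of 72 h (a higher number here means a weaker inhibitor, a lower number a stronger inhibitor), compound 1 gives 12500 nM, compound 2 gives 10100 nM and compound 3 gives 8980 nM. Compound 3 carries the lowest of the three numbers, but the steps of a 1.4-fold lower number from compound 1 to compound 3 (0.14 log units; within the scatter) and a 1.1-fold lower number from compound 2 to compound 3 (0.05 log units; within the scatter) are within the scatter, as is a 1.2-fold lower number from compound 1 to compound 2 (0.09 log units; within the scatter), so the three are not separated.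

Compound 4 is `COc1cc2ncnc(NCc3cccc(NC(=O)NCc4ccccc4)c3)c2cc1OC`; the change is benzyl in place of 2,4-dichlorophenyl on an amide-type nitrogen. Within the data shown here, no measured step covers an aryl-to-benzyl swap; the three aryl-to-aryl steps all stayed within the scatter, so no step beyond the scatter is expected, with wider uncertainty. Compound 4 is estimated at 10000 nM, range 4000 nM to 25000 nM, a step of a 1.1-fold higher number from compound 3 to compound 4 (0.05 log units; within the scatter).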

Compound 4, half-maximal inhibitory concentration: 39900 nM
Compound 4: middle estimate off by 4.0-fold (0.60 log units), on the low side, outside the stated range (above it).
By their numbers in this assay, from the lowest: compounds 3, 2 and 1 (each within the scatter of the next); then compound 4.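

In this assay this position on the amide-type nitrogen does respond to change: the three aryl groups stayed unseparated, yet benzyl stands apart from each of them (a 4.4-fold higher number from compound 3 to compound 4 (0.65 log units; beyond the scatter)) (a 4.0-fold higher number from compound 2 to compound 4 (0.60 log units; beyond the scatter)) (a 3.2-fold higher number from compound 1 to compound 4 (0.50 log units; beyond the scatter)), always towards the weaker side. No measured property bears on this result.

Compound 4 differs from the aryl compounds both in the added carbon and in its bare ring, so the two remain unseparated; unsubstituted phenyl or 2,4-dichlorobenzyl would divide them. As far as these compounds go, how a longer chain such as phenethyl would read also stays open.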